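A few compounds are considered here, and "the series" means these few. Any claim that something is new, unique, unknown or untested is made for them only; others in the source may bear on it.

Measured so far:
compound 1 `CNC(=O)CCCCCCCn1nc(-c2cnc3[nH]ccc3c2)c2c(N)ncnc21`: 100%
compound 2 `Nc1nc2cc(-c3nn(CCCCC(=O)NO)c4ncnc(N)c34)ccc2o1`: 95.1%
compound 3 `Nc1nc2cc(-c3nn(CCCCCCCCC(=O)NO)c4ncnc(N)c34)ccc2o1`: 99%

In an assay on isolated protein for inhibition of protein deacetylase HDAC6 (Homo sapiens), with a stated time of 15 min, tested at 1 uM (a higher number here means more inhibition at the concentration tested (going by the name of the read-out), a lower number less inhibition), compound 3 stands second highest of the three numbers; its gaps to compound 1 and to compound 2 both lie within the scatter, so no order among them is claimed. Compound 4 `CNC(=O)CCCCCCCn1nc(-c2ccc3oc(N)nc3c2)c2c(N)ncnc21` differs from compound 3 by methylcarbamoyl in place of (hydroxycarbamoyl)methyl on a saturated chain carbon, seven bonds along the chain from an aromatic nitrogen. Among the measured compounds shown here, the only measured step, a number 3.9 percentage points higher from compound 2 to compound 3 (within the scatter), concerns chain length alone and says nothing about this exchange. For the measured compounds named here, no measured pair carries the exchange itself; the nearest reference is compound 1, which bears the methylcarbamoyl end on a different core and in this assay gives 100%. Compound 4 is therefore expected at 96%, within 85% to 100%. The expected step is a number 3 percentage points lower from compound 3 to compound 4 (within the scatter), not beyond the scatter.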

Compound 4, a percentage reported as inhibition, at one concentration (the size of the read-out at that concentration, not a potency): 99.1%
Estimate against measurement, compound 4: 3.1 percentage points below, and the stated range covers the measured number.
By their numbers in this assay, from the lowest: compounds 2, 3, 4 and 1 (each within the scatter of the next).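

In this assay, methylcarbamoyl in place of (hydroxycarbamoyl)methyl leaves the reading within the scatter (a number 0.1 percentage points higher from compound 3 to compound 4 (within the scatter)), so at this one concentration the hydroxycarbamoyl end is not needed on the shared core. The comparison with the shorter hydroxycarbamoyl chain (a number 4 percentage points higher from compound 2 to compound 4 (within the scatter)) and the exchange of the group on the aromatic carbon (a number 0.9 percentage points lower from compound 1 to compound 4 (within the scatter)) also stay within the scatter. No evidence is available that explains these readings.

With all four readings this close, a single-concentration percentage does not separate the compounds. As far as these compounds go, whether a carboxylic acid or a primary amide at the chain end would give the same reading remains open.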